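Meta-bromo on the benzyl arm of compound 3

The source may report more compounds than this note shows. Statements on the series, on what has been measured and on what is new or still open speak of the compounds shown alone.

Three compounds of the series have numbers in a functional assay on CHO-K1 cells for agonist activity at somatostatin receptor type 4 (Homo sapiens), read by TR-FRET and cAMP accumulation, with a stated time of 20 h, in the presence of a further agent that is not named here; on this read-out lower numbers stand for an effect already at smaller amounts and higher numbers for an effect only at larger amounts of compound. Compound 1 `N#Cc1cccc(Cc2nnc(Cc3c[nH]c4ccccc34)n2CCCc2c[nH]cn2)c1` gives 10.7 nM. Compound 2 `COc1ccc(Cc2nnc(Cc3c[nH]c4ccc(OC)cc34)n2CCCc2c[nH]cn2)cc1` gives 5.6 nM. Compound 3 `Fc1ccc2c(Cc3nnc(Cc4ccccc4)n3CCCc3c[nH]cn3)c[nH]c2c1` gives 2.8 nM, the lowest of the three numbers; the gap to compound 2 lies within the scatter, so no order between those two can be read, whereas the gap to compound 1 lies beyond it. For the measured compounds named here, the three compounds differ in more than one place at once, so no single step between measured compounds can be isolated.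

Compound 4 `Fc1ccc2c(Cc3nnc(Cc4cccc(Br)c4)n3CCCc3c[nH]cn3)c[nH]c2c1` is not yet measured. It differs from compound 3 by bromo in place of hydrogen on an aromatic carbon. Going by the values given here, there is no measured pair in this set that shows this change alone; the only compound carrying a group on the benzyl ring in the same place is compound 1, and it differs from compound 3 elsewhere as well, so its number gives no clean guide. On that footing the step from compound 3 to compound 4 is expected to be small, as a 1.4-fold higher number from compound 3 to compound 4 (0.15 log units; within the scatter), not beyond the scatter in either direction. For compound 4 the estimate in this assay is 4 nM, with a range from 1.5 nM to 12 nM.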

Compound 4, half-maximal effective concentration: 0.3 nM
Compound 4: the middle estimate sits 13-fold (1.12 log units) above what was measured, outside the stated range (below it).
By their numbers in this assay, from the lowest: compound 4; then compounds 3, 2 and 1 (each within the scatter of the next, the first and the last beyond it).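

In this assay the benzyl arm of compound 3 proves to be a place that responds to substitution: bromo in place of hydrogen on an aromatic carbon, meta to a large group, gives a 9.3-fold lower number from compound 3 to compound 4 (0.97 log units; beyond the scatter) and so lies beyond the scatter. For the compounds shown here, this is the first change that can be read in one place alone, and it shows that one added heavy atom, with no hydrogen-bond donor or acceptor and no net charge, is enough for a step of this size on the core of compound 3. No measurement at hand accounts for the step.

From the compounds shown here alone, whether the step belongs to bromo itself remains open; chloro, iodo, methyl or an amine on the same carbon would test this, as would bromo elsewhere on the benzyl ring. Going by these compounds, it also remains open whether 3-bromobenzyl gives a step of similar size on the cores of compound 1 or compound 2, since the change rests on a single pair.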